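Methanesulfonamido for Methylcarbamoyl: Rat Clearance Outlook

The compounds below may be only part of what the source reports. "The series", "measured", "known", "first", "only" and "open" are said of these compounds alone.

Compound 1, `CNc1nc(NCc2ccc(OC(F)(F)F)cc2)cc(-c2ccccn2)n1`, in an ADME assay (liver) for pharmacokinetics, with Liver microsome (Rattus norvegicus) as the target, using microsomes (on this read-out higher numbers stand for fast clearance and lower numbers for slow clearance), gives only a limit, > 52.3 mL/min/kg.
Compound 2, `CNc1nc(NCc2ccc(S(C)(=O)=O)cc2)cc(-c2ccccn2)n1`, in this assay gives 34.1 mL/min/kg.
Compound 3, `CNC(=O)c1ccc(CNc2cc(-c3ccccn3)nc(NC)n2)cc1`, in this assay gives 31.9 mL/min/kg.

Compound 3 holds the lowest of the two numbers, with compound 2 nearest, a 1.1-fold lower number from compound 2 to compound 3 (0.03 log units; within the scatter). Compound 4, `CNc1nc(NCc2ccc(NS(C)(=O)=O)cc2)cc(-c2ccccn2)n1`, differs from compound 3 by methanesulfonamido in place of methylcarbamoyl on an aromatic carbon. Within the data shown here, the steps that bear on this are an at least 1.5-fold lower number from compound 1 to compound 2 (0.18 log units; that floor lies within the scatter) and an at least 1.6-fold lower number from compound 1 to compound 3 (0.21 log units; that floor lies within the scatter), both bounded by the limit of > 52.3 mL/min/kg in this assay, at which 1 of the 3 values shown sits, and the small 1.1-fold lower number from compound 2 to compound 3 (0.03 log units; within the scatter). Polar groups on this aromatic carbon have so far given numbers close together, so no step beyond the scatter is expected in this assay, a 1.0-fold higher number from compound 3 to compound 4 (0.00 log units; within the scatter). Compound 4 is therefore estimated at 32 mL/min/kg, between 18 mL/min/kg and 55 mL/min/kg.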

Compound 4, clearance: 33.6 mL/min/kg
Estimate against measurement, compound 4: 1.1-fold (0.02 log units) below; measured number inside the range.
By their numbers in this assay, from the lowest: compounds 3, 4 and 2 (each within the scatter of the next). At a limit, above all of these: compound 1.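

In this assay, methanesulfonamido is a third group on this aromatic carbon to leave the number where it was, with a 1.1-fold higher number from compound 3 to compound 4 (0.02 log units; within the scatter) and a 1.0-fold lower number from compound 2 to compound 4 (0.01 log units; within the scatter) as the two steps. Compounds 2, 3 and 4 therefore cannot be told apart, although methanesulfonamido differs from methylcarbamoyl in its heavy atoms and hydrogen-bond acceptors. As far as these compounds go, compound 1 remains a limit, so its step gives only a floor, an at least 1.5-fold lower number from compound 1 to compound 4 (0.19 log units; that floor lies within the scatter) and its true size stays unknown: the limit of > 52.3 mL/min/kg in this assay, at which 1 of the 4 values shown sits.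

From the compounds shown here alone, whether a carboxylic acid, an amine or a longer chain on this aromatic carbon would shift the number remains open.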